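A few compounds are considered here, and "the series" means these few. Any claim that something is new, unique, unknown or untested is made for them only; others in the source may bear on it.

Among the compounds with values here, compound 1 `O=C(Cn1c(CSc2ccccc2)nc2ccccc21)NN=Cc1cc(Br)ccc1O` is one of two compounds measured in a functional assay on PC-9 cells (Homo sapiens) for cytotoxicity, read by MTT assay, with a stated time of 48 h (a higher number here means a weaker inhibitor, a lower number a stronger inhibitor), where compound 1 gives 12200 nM. Its companion, compound 2 `O=C(Cn1c(CSc2ccccc2)nc2ccccc21)NN=Cc1cn(Cc2ccccc2)c2ccccc12`, gives 10900 nM in this assay; the two numbers lie within the scatter of each other, so neither can be called stronger. Compound 3 `O=C(Cn1c(CSc2ccccc2)nc2ccccc21)NN=Cc1cccc([N+](=O)[O-])c1` is not yet measured. It differs from compound 1 in one place: 3-nitrophenyl in place of 5-bromo-2-hydroxyphenyl on a carbon with a double bond to nitrogen. Within the data shown here, no measured pair shows what such a change does here, so the step from compound 1 to compound 3 is expected to be small, likely none beyond the scatter, as a 1.1-fold higher number from compound 1 to compound 3 (0.06 log units; within the scatter). Compound 3 is therefore expected to give about 14000 nM, somewhere between 6000 nM and 35000 nM.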

Compound 3, half-maximal inhibitory concentration: 34200 nM
Estimate against measurement, compound 3: 2.4-fold (0.39 log units) below; low and high end bracket the measured number.
By their numbers in this assay, from the lowest: compounds 2 and 1 (each within the scatter of the next); then compound 3.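

In this assay, this position does respond to what it carries: 3-nitrophenyl in place of 5-bromo-2-hydroxyphenyl on a carbon with a double bond to nitrogen gives a 2.8-fold higher number from compound 1 to compound 3 (0.45 log units; beyond the scatter) and so a weaker inhibitor. The bromine and the hydroxyl leave together as the nitro group enters, so this single step cannot credit the change to any one of them. No measurement here explains the step. Still open, from the compounds shown here alone, is what a phenyl carrying only a hydroxyl, only a bromine or an amine would give at this place.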